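The source may report more compounds than this note shows. Statements on the series, on what has been measured and on what is new or still open speak of the compounds shown alone.

Working notes on the series, following the step from compound 2 to compound 4.

Compound 2 `Cc1cccc(C(=O)N(C)c2ccc(C(O)(C(F)(F)F)C(F)(F)F)cc2)c1` is the point of departure. In an ADME assay on Li23 cells (Homo sapiens) for cytotoxicity, read by WST assay (on this read-out lower numbers stand for higher toxicity in this test and higher numbers for lower toxicity in this test), compound 2 gives 20000 nM, the highest of the two numbers in hand. Its nearest neighbour is compound 1 `Cc1cc(C(O)(C(F)(F)F)C(F)(F)F)ccc1N(C)C(=O)c1ccccc1`, which in this assay gives 9000 nM, a gap beyond the scatter. Compound 3 `CN(C(=O)c1ccccn1)c1ccc(C(O)(C(F)(F)F)C(F)(F)F)cc1` carries a pyridin-2-yl on the carbonyl carbon. In this assay compound 3 reaches only a limit, > 100000 nM. For the measured compounds named here, the one measured step that bears on the change under study is an at least 5.0-fold higher number from compound 2 to compound 3 (0.69 log units; beyond the scatter); that step rests on (the limit of > 100000 nM in this assay, at which 1 of the 3 values shown sits).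

Compound 4 `CN(C(=O)c1cccs1)c1ccc(C(O)(C(F)(F)F)C(F)(F)F)cc1` differs from compound 2 in one place: thiophen-2-yl in place of 3-methylphenyl on a carbonyl carbon. The thiophen-2-yl, like the pyridin-2-yl of compound 3, is a heteroaryl, but it is a five-membered ring with sulfur as its hetero atom. The step from compound 2 to compound 3 is a guide rather than a template. A rise is expected, smaller than in the pyridine case, and an outcome within the scatter cannot be excluded. The expected step is a 1.5-fold higher number from compound 2 to compound 4 (0.18 log units; within the scatter). For compound 4 in this assay the estimate is 30000 nM, with a range from 12000 nM to 80000 nM.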

Compound 4, half-maximal cytotoxic concentration: 33000 nM
Estimate against measurement, compound 4: 1.1-fold (0.04 log units) below; the measured number falls inside the stated range.
By their numbers in this assay, from the lowest: compound 1; then compounds 2 and 4 (each within the scatter of the next). At a limit, above all of these: compound 3.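

Exchanging 3-methylphenyl for thiophen-2-yl on the carbonyl carbon does not move the read-out in this assay beyond the scatter, with a 1.7-fold higher number from compound 2 to compound 4 (0.22 log units; within the scatter), so at this position a five-membered aromatic ring with one hetero atom reads like the six-membered carbon ring it replaces. For the compounds shown here, compound 4 also separates the two heteroaryl groups, which the earlier compounds could not do: the series shows an at least 3.0-fold lower number from compound 3 to compound 4 (0.48 log units; beyond the scatter), so having a heteroaryl on this carbonyl carbon does not by itself bring the read-out to the level of compound 3. Compound 3 stands at a limit and not at a number, so the true size of that step remains unknown, and the comparison fixes only its direction: the limit of > 100000 nM in this assay, at which 1 of the 4 values shown sits.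

The compounds shown leave open whether the result for compound 3 is tied to the pyridin-2-yl group itself, since neither a pyridin-3-yl nor a furan-2-yl group on the same carbonyl carbon is among them. They also give no reading for a phenyl ring carrying an amine or a carboxylic acid at this place, and nothing here accounts for the difference between compound 3 and compound 4.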